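From Morpholin-4-yl to 4-Acetylpiperazin-1-yl: Expected Solubility

The source may report more compounds than this note shows. Statements on the series, on what has been measured and on what is new or still open speak of the compounds shown alone.

Three compounds have been measured in a physicochemical assay for solubility, read by HPLC, at pH 6.8; on this read-out lower numbers stand for lower solubility and higher numbers for higher solubility:

compound 1 `CC(C)(C)c1cc(NC(=O)[C@@H]2CCCCN2C(=O)c2ccccc2)no1` gives 0.9 ug/mL
compound 2 `CC(C)(C)c1cc(NC(=O)[C@@H]2CCCCN2C(=O)N2CCCCC2)no1` gives 49 ug/mL
compound 3 `CC(C)(C)c1cc(NC(=O)[C@@H]2CCCCN2C(=O)N2CCOCC2)no1` gives 45 ug/mL

Compound 3 stands second highest of the three numbers in this assay; it sits within the scatter of compound 2, and far above compound 1, as a 50-fold higher number from compound 1 to compound 3 (1.70 log units; beyond the scatter) shows. The step to compound 4 `CC(=O)N1CCN(C(=O)N2CCCC[C@H]2C(=O)Nc2cc(C(C)(C)C)on2)CC1` is 4-acetylpiperazin-1-yl in place of morpholin-4-yl on a carbonyl carbon.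

For the measured compounds named here, two measured steps bear on this change. The exchange of one saturated six-membered ring for another on the same carbonyl carbon, a 1.1-fold lower number from compound 2 to compound 3 (0.04 log units; within the scatter), stayed within the scatter. The large steps of a 54-fold higher number from compound 1 to compound 2 (1.74 log units; beyond the scatter) and a 50-fold higher number from compound 1 to compound 3 (1.70 log units; beyond the scatter) came from replacing phenyl with a saturated ring bearing a nitrogen; compound 4 keeps such a ring. Compound 4 is therefore expected to stay close to compound 3, with a 1.2-fold higher number from compound 3 to compound 4 (0.09 log units; within the scatter), no change beyond the scatter being expected. Compound 4 is estimated at 55 ug/mL in this assay, with a range from 22 ug/mL to 140 ug/mL.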

Compound 4, solubility: 62 ug/mL
For compound 4 the middle estimate is 1.1-fold (0.05 log units) below the measured one; measured number inside the range.
By their numbers in this assay, from the lowest: compound 1; then compounds 3, 2 and 4 (each within the scatter of the next).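

On the carbonyl carbon, 4-acetylpiperazin-1-yl leaves the reading in this assay level with the two saturated rings already measured, since a 1.4-fold higher number from compound 3 to compound 4 (0.14 log units; within the scatter) and a 1.3-fold higher number from compound 2 to compound 4 (0.10 log units; within the scatter) both stay within the scatter. The large difference from phenyl also extends to this third ring, with a 69-fold higher number from compound 1 to compound 4 (1.84 log units; beyond the scatter), so among these compounds the three saturated rings stand apart from phenyl but not from one another, even with an acetyl group on the ring. No measurement available here gives a reason for this flat result.

The compounds shown leave open whether 4-methylpiperazin-1-yl, which carries an amine in place of the acetyl group, would stay level with these rings. Nor do they settle whether an open-chain dimethylamino group or a ring bearing a carboxylic acid would do so.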